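A few compounds are considered here, and "the series" means these few. Any claim that something is new, unique, unknown or untested is made for them only; others in the source may bear on it.

Values in a functional assay on V79 cells (Cricetulus griseus) for cytotoxicity, read by colony formation; a higher number here means a weaker inhibitor, a lower number a stronger inhibitor:
- compound 1 `NCC1CCN(c2c(F)cc3c(=O)c(C(=O)O)cn(C4CC4)c3c2C(F)(F)F)C1`: 38 ug/mL
- compound 2 `CCNCC1CCN(c2nc3c(cc2F)c(=O)c(C(=O)O)cn3C2CC2)C1`: 160 ug/mL
- compound 3 `CNCC1(C)CCN(c2nc3c(cc2F)c(=O)c(C(=O)O)cn3C2CC2)C1`: 58 ug/mL

Compound 3, at 58 ug/mL, lies within the scatter of compound 1 and well under compound 2, so it sits with the lower numbers in this small set.

The next compound is compound 4 `CC1CN(c2nc3c(cc2F)c(=O)c(C(=O)O)cn3C2CC2)CC(C)N1`, which carries 3,5-dimethylpiperazin-1-yl in place of 3-methyl-3-((methylamino)methyl)pyrrolidin-1-yl on an aromatic carbon, ortho to a fluoro group: 3,5-dimethylpiperazin-1-yl in place of 3-methyl-3-((methylamino)methyl)pyrrolidin-1-yl on an aromatic carbon.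

Within the data shown here, only one measured step comes close to this change: a 2.8-fold lower number from compound 2 to compound 3 (0.44 log units; beyond the scatter). It is modest and exchanges one pyrrolidinyl group for another, so it shows that this substituent can move this assay but says nothing directly about a piperazinyl group. Among the measured compounds shown here, no measured compound carries one. A step of about that modest size at most is therefore expected, with no firm direction and a slight lean towards a higher number.

The expected step is a 1.3-fold higher number from compound 3 to compound 4 (0.11 log units; within the scatter). For compound 4 the estimate is 75 ug/mL, with an expected range from 30 ug/mL to 190 ug/mL.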

Compound 4, half-maximal inhibitory concentration: 250 ug/mL
Compound 4: the middle estimate sits 3.3-fold (0.52 log units) below what was measured, outside the stated range (above it).
By their numbers in this assay, from the lowest: compounds 1 and 3 (each within the scatter of the next); then compounds 2 and 4 (each within the scatter of the next).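

In this assay, 3,5-dimethylpiperazin-1-yl in place of 3-methyl-3-((methylamino)methyl)pyrrolidin-1-yl on this aromatic carbon gives a 4.3-fold higher number from compound 3 to compound 4 (0.63 log units; beyond the scatter), which shows that a change of ring at this position can move the number beyond the scatter. Against 3-((ethylamino)methyl)pyrrolidin-1-yl, the same piperazinyl group gives a 1.6-fold higher number from compound 2 to compound 4 (0.19 log units; within the scatter), so a six-membered ring in itself does not set this compound apart from every pyrrolidinyl analogue, and the outcome depends on which pyrrolidinyl group it replaces. Nothing available explains the difference between these substituents.

The compounds shown do not separate the effect of ring size from that of the two ring methyl groups or of the aminomethyl side chains. On these data alone, an unsubstituted piperazin-1-yl group at this position would help to separate them, and whether the same ordering holds on the core of compound 1 remains open.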